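From Iodo to Methylamino: Notes on One Step

The source may hold more compounds than are shown below. What is called first, only, known or untested is meant among the compounds shown, and "the series" means these compounds.

In an ADME assay on L1210/0 cells (Mus musculus) for cytotoxicity, with a stated time of 48 h (on this read-out lower numbers stand for stronger inhibition and higher numbers for weaker inhibition), compound 1 (`COc1ccc(-c2ncnc3c2ncn3C[C@@H]2C[C@H](CO)c3ccccc32)cc1`) gives 17600 nM. Compound 2 (`Nc1nc2c(nc(I)n2COCCO)c(=O)[nH]1`) gives 111000 nM, the higher of the two numbers in this set, and the gap to compound 1 lies beyond the scatter. Compound 3 (`Nc1ncnc2c1ncn2CC1CCC(CO)C1`) returns only a limit and not a number, > 200000 nM.

The next compound to be read is compound 4 (`CNc1nc2c(=O)[nH]c(N)nc2n1COCCO`). It has methylamino in place of iodo on an aromatic carbon of a five-membered aromatic ring with 2 nitrogen: methylamino in place of iodo on an aromatic carbon. Going by the values given here, no measured step in the set covers this change, so the expectation rests on a single comparator. Among the compounds with values here, compound 2, at 111000 nM, is the only measured compound that carries the (2-hydroxyethoxy)methyl group. With nothing to indicate a size or a direction, no shift beyond the scatter is expected in this assay. The estimate for a 1.1-fold higher number from compound 2 to compound 4 (0.03 log units; within the scatter) therefore stays within the scatter. A reading for compound 4 could also end at the limit of > 200000 nM in this assay, at which 1 of the 3 values shown sits, and that outcome is kept open as a real possibility. For compound 4 the estimated value is 120000 nM, with an expected range of 50000 nM to 200000 nM.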

Compound 4, half-maximal inhibitory concentration: > 200000 nM
Compound 4: a limit, no number; the forecaster's own chance of this, stated with the estimate: 35%; middle value at least 1.6-fold (0.22 log units) from the limit.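

In this assay compound 4 gives > 200000 nM, which is a limit of the assay and not a number. Going by these compounds alone, this gives the first read on a change on the aromatic carbon between two ring nitrogen atoms, and the step is an at least 1.8-fold higher number from compound 2 to compound 4 (0.25 log units; that floor lies within the scatter); methylamino in place of iodo therefore brings no gain in inhibition over compound 2, but the floor of the step does not establish a real loss, and its true size stays unread. Within the data shown here, with the (2-hydroxyethoxy)methyl group unchanged, the iodo compound remains the only one carrying that group with a measured number, and the ceiling of the read-out is now reached twice: the limit of > 200000 nM in this assay, at which 2 of the 4 values shown sit.

Still open, going by these compounds, is whether the number of compound 2 depends on iodo specifically, or whether a smaller halogen such as chloro or a plain hydrogen on this carbon would keep a reading under the limit. Also open, on these data alone, is whether a primary amine, a dimethylamino group or a longer chain such as butylamino on the same carbon would return a number at all, and so give this position a measurable trend.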